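The source may hold more compounds than are shown below. What is called first, only, known or untested is meant among the compounds shown, and "the series" means these compounds.

For the measured compounds named here, compound 2 `CC(CS(C)(=O)=O)OCn1cc[n+](C)c1/C=N/O` stands at the more polar end of the two compounds measured so far in a physicochemical assay for lipophilicity; a higher number here means a more lipophilic compound, a lower number a more polar compound: in this assay compound 2 gives -2.66, while compound 1 `CC(CCC[N+](=O)[O-])OCn1cc[n+](C)c1/C=N/O` gives -2.11. Going by the values given here, the one measured step, a number 0.55 log units lower from compound 1 to compound 2 (beyond the scatter), concerns a different exchange on the chain and so speaks only loosely to what follows. Compound 3 `CCS(=O)(=O)CC(C)OCn1cc[n+](C)c1/C=N/O` differs from compound 2 by methyl in place of hydrogen on a saturated chain carbon bound to a sulfonyl sulfur. Among the compounds with values here, no measured pair covers an exchange of this kind, so the expectation rests on compound 2 with its -2.66 and on the size of the single known step as a sense of scale. A small rise, a number 0.36 log units higher from compound 2 to compound 3 (beyond the scatter), is estimated for the move to compound 3, modest next to the step between compound 1 and compound 2. Compound 3 is therefore expected to give -2.3, with a likely range from -2.7 to -1.9.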

Compound 3, distribution coefficient: -2.7
Estimate against measurement, compound 3: 0.40 log units above, within the range that was stated.
By their numbers in this assay, from the lowest: compounds 3 and 2 (each within the scatter of the next); then compound 1.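

In this assay, methyl in place of hydrogen on a saturated chain carbon bound to a sulfonyl sulfur, which turns methylsulfonyl into ethylsulfonyl, amounts to a number 0.04 log units lower from compound 2 to compound 3 (within the scatter) and so leaves no readable mark on the number at this position. Measured against the nitro-bearing chain, the ethylsulfonyl group gives a number 0.59 log units lower from compound 1 to compound 3 (beyond the scatter), a step of much the same size as a number 0.55 log units lower from compound 1 to compound 2 (beyond the scatter), so the two sulfonyl compounds stand together, apart from compound 1. The one extra carbon on the sulfonyl group thus makes no difference that can be read here, though this rests on a single pair. Going by these compounds, whether a longer chain such as propyl or butyl on the sulfonyl sulfur, or an amine at the end of that chain, would also leave the number in place stays open. Nothing at hand gives a reason for either step.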